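Chain substituent swap in the aryl enone series

The source may hold more compounds than are shown below. What is called first, only, known or untested is meant among the compounds shown, and "the series" means these compounds.

Compound 3 `COc1ccc(C(=O)/C(=C/c2ccc(Cl)cc2)CCOC(C)=O)cc1` in a functional assay on NB-4 cells (Homo sapiens) for inhibition, read by XTT assay, with a stated time of 48 h (a higher number here means a weaker inhibitor, a lower number a stronger inhibitor), gives 36300 nM. Its closest companion among the measured compounds is compound 2 `COc1ccc(C(=O)/C(=C/c2ccc(Cl)cc2Cl)CCOC(C)=O)cc1`, which gives 34800 nM in this assay, and the two sit within the scatter of each other. Compound 1 `COc1ccc(C(=O)/C(=C/c2ccccc2F)CCOC(C)=O)cc1` in this assay yields only a limit, > 100000 nM, as the limit of > 100000 nM in this assay, at which 1 of the 3 values shown sits, sets out. Every measured step changes the aryl group on the double-bonded chain carbon: an at least 2.8-fold lower number from compound 1 to compound 2 (0.45 log units; beyond the scatter), an at least 2.7-fold lower number from compound 1 to compound 3 (0.44 log units; beyond the scatter), and a 1.0-fold higher number from compound 2 to compound 3 (0.02 log units; within the scatter).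

Compound 4 `COc1ccc(C(=O)/C(=C/c2ccc(Cl)cc2)CC(C)C)cc1` differs from compound 3 in the chain: isopropyl in place of acetoxymethyl on a saturated chain carbon bound to a double-bonded chain carbon. Within the data shown here, none of the measured steps touches this position; they bear on the aryl group alone, so they give no direct reading on how this assay answers a change in the chain. The two steps from compound 1 show that one change at one place can move the number beyond the scatter, while the step between compound 2 and compound 3 shows that it can also leave the number where it was. Among the measured compounds shown here, with no chain step available, the expectation is for no movement beyond the scatter, with a wide range around it. The expected step in this assay is a 1.2-fold lower number from compound 3 to compound 4 (0.08 log units; within the scatter). Compound 4 is estimated in this assay at 30000 nM, with a range from 8000 nM to 120000 nM.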

Compound 4, half-maximal inhibitory concentration: 12100 nM
Estimate against measurement, compound 4: 2.5-fold (0.39 log units) above; low and high end bracket the measured number.
By their numbers in this assay, from the lowest: compound 4; then compounds 2 and 3 (each within the scatter of the next). At a limit, above all of these: compound 1.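

In this assay, among these compounds, the chain position turns out not to be silent: a 3.0-fold lower number from compound 3 to compound 4 (0.48 log units; beyond the scatter) is the first measured step away from the aryl group, and it is beyond the scatter, though modest. Acetoxymethyl is therefore not required to hold the number of compound 3 with 4-chlorophenyl in place; the group that replaces it has no hydrogen-bond acceptors and no double bond, and the number still falls. Nothing at hand tells which part of the swap, whether the loss of those features or the smaller group, accounts for the step.

Going by these compounds, this reading rests on one pair, so it remains open whether the same swap moves the number equally with 2,4-dichlorophenyl or 2-fluorophenyl on the double-bonded chain carbon. On these data alone, it also remains open how this saturated chain carbon would respond to an amine, a carboxylic acid, a free hydroxyl or a longer alkyl chain, and whether any of these would carry the number further than isopropyl does.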